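Cyclopropylamino in place of hydroxypropylamino on the shared core

A few compounds are considered here, and "the series" means these few. Any claim that something is new, unique, unknown or untested is made for them only; others in the source may bear on it.

Measured compounds:
compound 1 `OCCCNc1nc(-c2ccccc2)nc2c1nnn2Cc1ccccc1Cl`: 33000000 nM in an assay on isolated protein for binding affinity to adenosine receptor A1 (Bos taurus); on this read-out higher numbers stand for weaker inhibition and lower numbers for stronger inhibition
compound 2 `OCCCNc1nc(-c2ccccc2)nc2c1nnn2Cc1ccccc1`: 21400000 nM
compound 3 `CCCNc1nc(-c2ccccc2)nc2c1nnn2Cc1ccccc1`: 37000000 nM

All three numbers lie within the usual scatter of one another. Compound 1 has compound 3 as its closest neighbour and compound 2 as its furthest, and neither gap is beyond the scatter. The two steps seen so far are small: a 1.5-fold lower number from compound 1 to compound 2 (0.19 log units; within the scatter) and a 1.7-fold higher number from compound 2 to compound 3 (0.24 log units; within the scatter).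

Compound 4 `Clc1ccccc1Cn1nnc2c(NC3CC3)nc(-c3ccccc3)nc21` keeps the chloro on the aromatic ring of compound 1 and differs only at the amino group: cyclopropyl in place of 3-hydroxypropyl on a nitrogen on an aromatic ring. For the measured compounds named here, no measured step changes this position in the same way; the closest is the step from compound 2 to compound 3, where the hydroxy is removed from the same chain, and it stays within the scatter. The expectation is therefore for no change beyond the scatter in this assay, with the same weak binding as the rest of the series.

Compound 4 is estimated at 30000000 nM, with a range from 10000000 nM to 100000000 nM, a step of a 1.1-fold lower number from compound 1 to compound 4 (0.04 log units; within the scatter).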

Compound 4, inhibition constant: 11000000 nM
Beside the measured number, compound 4's estimate is 2.7-fold (0.44 log units) above it; the measured number falls inside the stated range.
By their numbers in this assay, from the lowest: compounds 4, 2, 1 and 3 (each within the scatter of the next, the first and the last beyond it).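

In this assay, cyclopropyl in place of 3-hydroxypropyl on the nitrogen gives a 3.0-fold lower number from compound 1 to compound 4 (0.48 log units; beyond the scatter), a modest change and the only step shown that lies beyond the scatter. The amino substituent is therefore the one position here where a change registers, whereas removing the hydroxy from the same chain in the compounds without chloro gave only a 1.7-fold higher number from compound 2 to compound 3 (0.24 log units; within the scatter), which stays within the scatter. No evidence on the cause of the new step is available.

The change removes the hydroxy, shortens the chain and adds a ring in one step, so the compounds shown do not separate these contributions. As far as these compounds go, it also remains open whether a cyclobutyl or an isopropyl on the same nitrogen would give a similar step, and whether cyclopropyl would do so without the chloro.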